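The source may hold more compounds than are shown below. What is called first, only, known or untested is meant among the compounds shown, and "the series" means these compounds.

Compound 1, `CC(C)COc1ccc(NC(=O)CCCCCCCSc2nnc(Cc3nn(C)c(=O)c4ccccc34)n2C)cc1`, and compound 3, `Cn1c(Cc2nn(C)c(=O)c3ccccc23)nnc1SCCCCCCCC(=O)Nc1ccc(Cl)cc1Cl`, share a core and differ in one place: 2,4-dichlorophenyl in place of 4-(isobutoxy)phenyl on an amide-type nitrogen. In an assay on isolated protein (Mus musculus) for inhibition of IL15-IL15 receptor (Homo sapiens), read by resazurin assay, with stated times of 30 min and 2.5 days (a lower number here means a stronger inhibitor, a higher number a weaker inhibitor), compound 1 gives 4800 nM, while compound 3 gives 1900 nM, so the step is a 2.5-fold lower number from compound 1 to compound 3 (0.40 log units; beyond the scatter). Compound 2, `CC(C)COc1ccc(NC(=O)CSc2nnc(Cc3nn(C)c(=O)c4ccccc34)n2C)cc1`, carries a shorter link between the core and the amide; how its core differs from that of compound 1 is not broken down here. In this assay compound 2 gives 30000 nM, the highest of the three numbers, and the gaps to compound 1 and compound 3 lie beyond the scatter. Compound 4, `Cn1c(Cc2nn(C)c(=O)c3ccccc23)nnc1SCC(=O)Nc1ccc(Cl)cc1Cl`, has not yet been measured; it differs from compound 2 by 2,4-dichlorophenyl in place of 4-(isobutoxy)phenyl on an amide-type nitrogen, the same change, at the same place, as that from compound 1 to compound 3. He expects a step of a 2.5-fold lower number from compound 2 to compound 4 (0.40 log units; beyond the scatter) in this assay, similar in size to the earlier one, because that earlier step was a 2.5-fold lower number from compound 1 to compound 3 (0.40 log units; beyond the scatter). He therefore estimates for compound 4 a value of 12000 nM, within 5000 nM and 40000 nM.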

Compound 4, half-maximal inhibitory concentration: 17300 nM
The estimate for compound 4 lay 1.4-fold (0.16 log units) below the measured number; low and high end bracket the measured number.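

On the core of compound 2, putting 2,4-dichlorophenyl in place of 4-(isobutoxy)phenyl on the amide-type nitrogen gives a 1.7-fold lower number from compound 2 to compound 4 (0.24 log units; within the scatter) in this assay, so on this core the change alone cannot be told apart from the scatter of repeated measurements. Set beside the earlier step, the new one does not differ from it by more than such scatter, so as far as these four compounds can show, the change carries from one core to the other: the same change on two cores in this assay, a 2.5-fold lower number (0.40 log units; beyond the scatter) from compound 1 to compound 3 and a 1.7-fold lower number (0.24 log units; within the scatter) from compound 2 to compound 4, 1.5-fold (0.16 log units) apart, within the scatter of two such steps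

Among the compounds shown here, this rests on only two pairs, and it shows neither that the change would carry to any further core nor that it lowers the number on every core.

The compounds shown leave open how the change behaves with a chain of intermediate length in the link to the amide. They also leave open whether a phenyl group bearing an amine or a carboxylic acid on the amide-type nitrogen would follow the same course.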